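Replacing the 3-bromo-4-fluorophenyl group of compound 3

A few compounds are considered here, and "the series" means these few. Any claim that something is new, unique, unknown or untested is made for them only; others in the source may bear on it.

In a functional assay on A549 cells (Homo sapiens) for inhibition, read by MTT assay, with a stated time of 72 h (on this read-out lower numbers stand for stronger inhibition and higher numbers for weaker inhibition), compound 1 `COc1ccc(NC(=O)C2CCN(C/C=C/c3ccccc3)CC2)cc1` gives 83800 nM. Compound 2 `COc1ccccc1NC(=O)C1CCN(C/C=C/c2ccccc2)CC1` gives > 100000 nM, which is a limit of the assay. Among the compounds with values here, compound 3 `O=C(Nc1ccc(F)c(Br)c1)C1CCN(C/C=C/c2ccccc2)CC1` gives 11700 nM, the lowest number so far. Compound 4 `O=C(Nc1nccs1)C1CCN(C/C=C/c2ccccc2)CC1` differs from it in one place: 1,3-thiazol-2-yl in place of 3-bromo-4-fluorophenyl on an amide-type nitrogen. Within the data shown here, two measured steps bear on this change, and both introduce the 3-bromo-4-fluorophenyl group in place of a methoxyphenyl group: a 7.2-fold lower number from compound 1 to compound 3 (0.86 log units; beyond the scatter) and an at least 8.5-fold lower number from compound 2 to compound 3 (0.93 log units; beyond the scatter). Among the measured compounds shown here, no measured compound carries a 1,3-thiazol-2-yl group, so the link is indirect. Removing the 3-bromo-4-fluorophenyl group is expected to give back much of that gain in this assay. The estimated step is a 3.8-fold higher number from compound 3 to compound 4 (0.59 log units; beyond the scatter). The estimate for compound 4 is 45000 nM, within a range from 14000 nM to 100000 nM.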

Compound 4, half-maximal inhibitory concentration: 34900 nM
For compound 4 the middle estimate is 1.3-fold (0.11 log units) above the measured one; measured number inside the range.
By their numbers in this assay, from the lowest: compound 3; then compound 4; then compound 1. At a limit, above all of these: compound 2.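

In this assay, a five-membered aromatic ring with hetero atoms is tolerated on this amide-type nitrogen, but the 1,3-thiazol-2-yl group does not match the 3-bromo-4-fluorophenyl group: a 3.0-fold higher number from compound 3 to compound 4 (0.47 log units; beyond the scatter). It still gives a lower number than the 4-methoxyphenyl group, with a 2.4-fold lower number from compound 1 to compound 4 (0.38 log units; beyond the scatter), so a halogenated phenyl ring is not needed for some improvement over that compound. Against compound 2 only a floor can be read, an at least 2.8-fold lower number from compound 2 to compound 4 (0.45 log units; beyond the scatter), since compound 2 stands at a limit: the limit of > 100000 nM in this assay, at which 1 of the 4 values shown sits.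

On these data alone, whether a plain phenyl or a pyridin-2-yl group would fall nearer compound 3 or compound 4 remains open. So does how much of the lower number of compound 3 comes from its bromine and how much from its fluorine.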